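A few compounds are considered here, and "the series" means these few. Any claim that something is new, unique, unknown or untested is made for them only; others in the source may bear on it.

Measured so far:
- compound 1, with the structure `CCCCCCCCCCCCCCCCCCNC(=O)[C@@H](N)[C@@H](C)O`, gives 27400 nM in a functional assay on MCF7 cells (Homo sapiens) for cytotoxicity, read by MTT assay, with a stated time of 48 h; on this read-out lower numbers stand for stronger inhibition and higher numbers for weaker inhibition
- compound 2, with the structure `CCCCCCCCCCCCCCCCCCNC(=O)[C@@H](NC(=O)/C=C/c1ccccc1)[C@@H](C)O`, gives 39200 nM in this assay

Compound 2 holds the highest of the two numbers measured, and its nearest neighbour is compound 1, separated by a step that stays within the scatter. That single measured step, a 1.4-fold higher number from compound 1 to compound 2 (0.16 log units; within the scatter), is the only one available, and it shows that adding the (2-phenylethenyl)carbonyl group to the amine nitrogen did not move the read-out beyond noise.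

Compound 3, with the structure `C/C=C/C=C/C(=O)N[C@H](C(=O)NCCCCCCCCCCCCCCCCCC)[C@@H](C)O`, is not yet measured. It differs from compound 2 by prop-1-en-1-yl in place of phenyl on a double-bonded chain carbon bound to a double-bonded chain carbon. Within the data shown here, because the one measured step, a 1.4-fold higher number from compound 1 to compound 2 (0.16 log units; within the scatter), stayed within the scatter even for a larger addition on the same nitrogen, no step beyond the scatter is expected here either, in either direction.

Compound 3 is therefore expected to give about 35000 nM in this assay, with a likely range from 15000 nM to 85000 nM, which means an expected step of a 1.1-fold lower number from compound 2 to compound 3 (0.05 log units; within the scatter).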

Compound 3, half-maximal inhibitory concentration: 79600 nM
For compound 3 the middle estimate is 2.3-fold (0.36 log units) below the measured one; low and high end bracket the measured number.
By their numbers in this assay, from the lowest: compounds 1 and 2 (each within the scatter of the next); then compound 3.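

Among these compounds, on the amine nitrogen, the far end of the acyl group turns out to matter: in this assay, prop-1-en-1-yl in place of phenyl gives a 2.0-fold higher number from compound 2 to compound 3 (0.31 log units; beyond the scatter), the first step at this position that lies beyond the scatter, and it points toward weaker inhibition. Set against the free amine, the (penta-1,3-dien-1-yl)carbonyl group gives a 2.9-fold higher number from compound 1 to compound 3 (0.46 log units; beyond the scatter), while the (2-phenylethenyl)carbonyl group gives only a 1.4-fold higher number from compound 1 to compound 2 (0.16 log units; within the scatter), which stays within the scatter, so these two acyl groups on the same nitrogen do not behave alike, although both steps beyond the scatter are modest. Nothing available here explains why the number rises with this change.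

From the compounds shown here alone, the three compounds show no group on this nitrogen that brings the number below that of compound 1, so it remains open whether any group can strengthen inhibition from this position. Also open, going by these compounds, is how a saturated pentanoyl group, a small acetyl group or an acyl chain ending in a carboxylic acid or an amine would compare, and whether the phenyl ring itself or the chain of double bonds is what separates compound 2 from compound 3.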